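A few compounds are considered here, and "the series" means these few. Any claim that something is new, unique, unknown or untested is made for them only; others in the source may bear on it.

Of the compounds shown here, three built on a shared core have been measured in an ADME assay on L6 cells (Rattus norvegicus) for cytotoxicity, read by resazurin assay, with a stated time of 70 h; a higher number here means a weaker inhibitor, a lower number a stronger inhibitor. Compound 1, `N=C(N)c1ccc2cc(-c3cccc(OCCCCOc4ccccc4)c3)oc2c1`, gives 7600 nM in this assay. Compound 2, `N=C(N)c1ccc2cc(-c3cccc(OCCCCCOc4ccccc4)c3)oc2c1`, gives 4100 nM; it differs from compound 1 by phenoxymethyl in place of phenoxy on a saturated chain carbon, four bonds along the chain from an oxygen on an aromatic ring, and the step reads a 1.9-fold lower number from compound 1 to compound 2 (0.27 log units; within the scatter). Compound 3, `N=C(N)c1ccc2cc(-c3ccc(OCCCOc4ccccc4)cc3)oc2c1`, gives 8600 nM in this assay; the difference between the core of compound 1 and the core of compound 3 is not broken down here, and the two values lie within the scatter of each other. Compound 4, `N=C(N)c1ccc2cc(-c3ccc(OCCCCOc4ccccc4)cc3)oc2c1`, has not yet been measured. It differs from compound 3 by phenoxymethyl in place of phenoxy on a saturated chain carbon, three bonds along the chain from an oxygen on an aromatic ring. Going by the values given here, this is the same kind of change as the one from compound 1 to compound 2, though not the same: there the group sat four bonds along the chain from an oxygen on an aromatic ring, here it sits three bonds along the chain from an oxygen on an aromatic ring. Because the earlier change gave a 1.9-fold lower number from compound 1 to compound 2 (0.27 log units; within the scatter), a step of about that size is expected here: a 1.7-fold lower number from compound 3 to compound 4 (0.24 log units; within the scatter). Compound 4 is therefore estimated at 5000 nM, with a range from 2500 nM to 10000 nM.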

Compound 4, half-maximal inhibitory concentration: 14100 nM
The estimate for compound 4 lay 2.8-fold (0.45 log units) below the measured number, and the stated range ends below it.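

In this assay, putting phenoxymethyl in place of phenoxy gives a 1.6-fold higher number from compound 3 to compound 4 (0.21 log units; within the scatter), a step that on its own is small. Set beside the earlier step, it shows that the change does not carry from one core to the other as a fixed amount: the same change on two cores in this assay, a 1.9-fold lower number (0.27 log units; within the scatter) from compound 1 to compound 2 and a 1.6-fold higher number (0.21 log units; within the scatter) from compound 3 to compound 4, 3.0-fold (0.48 log units) apart, beyond the scatter of two such steps. Each core is represented by a single pair, and neither step alone lies beyond the scatter, so this does not show a reliable effect of the change on either core; nor can it separate the core from the place of the change, which sits three bonds along the chain from an oxygen on an aromatic ring in one pair and four in the other.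

The compounds shown leave open whether a longer chain, such as 2-phenoxyethyl in place of phenoxymethyl, would follow either step on either core. They also leave open how the same change would read with an amine or a carboxylic acid on the phenoxy ring.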